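The compounds below may be only part of what the source reports. "The series", "measured", "known", "first", "only" and "open" are said of these compounds alone.

Working notes on the series in a functional assay on NCI-H460 cells (Homo sapiens) for cytotoxicity, read by MTT assay, with a stated time of 3 days; a higher number here means a weaker inhibitor, a lower number a stronger inhibitor. Of the compounds shown here, two have been measured so far: compound 1 `CNc1nc(SCc2nc3ccccc3[nH]2)nc(-c2ccccc2)c1C#N` gives 3.2 nM, and compound 2 `N#Cc1c(Nc2ccccn2)nc(SCc2nc3ccccc3[nH]2)nc1-c1ccccc1` gives 2.8 nM. These two values lie within the scatter of each other, so compound 2 stands level with compound 1 and the pair cannot be ranked.

The next change leads to compound 3 `N#Cc1c(Nc2nccs2)nc(SCc2nc3ccccc3[nH]2)nc1-c1ccccc1`, and it is counted as follows: 1,3-thiazol-2-yl in place of pyridin-2-yl on a nitrogen on an aromatic ring. The rest of the structure is unchanged. Among the compounds with values here, only one measured step bears on this place: a 1.1-fold lower number from compound 1 to compound 2 (0.06 log units; within the scatter). It exchanged methyl for pyridin-2-yl on the same nitrogen and stayed within the scatter. Within the data shown here, that is a single step, and no measured compound yet carries 1,3-thiazol-2-yl. The evidence is thin, and the range is kept wide for that reason. No step beyond the scatter is expected here, in either direction. The expected size of the change is a 1.1-fold higher number from compound 2 to compound 3 (0.03 log units; within the scatter). Compound 3 is estimated at 3 nM, with an expected range of 1.2 nM to 9 nM.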

Compound 3, half-maximal inhibitory concentration: 3.37 nM
Estimate against measurement, compound 3: 1.1-fold (0.05 log units) below; the range from low to high includes it.
By their numbers in this assay, from the lowest: compounds 2, 1 and 3 (each within the scatter of the next).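

In this assay, the exchange of the six-membered pyridin-2-yl for the five-membered 1,3-thiazol-2-yl on the nitrogen gives a 1.2-fold higher number from compound 2 to compound 3 (0.08 log units; within the scatter), and the exchange of methyl for the same group gives a 1.1-fold higher number from compound 1 to compound 3 (0.02 log units; within the scatter). With a second aromatic ring now on this nitrogen, and one with a different ring size and a sulfur atom, the place has carried methyl and two different aromatic rings with no step beyond the scatter, so compounds 1, 2 and 3 stand level and cannot be ranked. No accompanying measurement bears on this flat result, and the values alone give no reason for it.

The three compounds leave open whether this place stays level with groups of another kind on the same nitrogen, such as a carboxylic acid, a primary amine at the end of a longer chain, or a larger fused aromatic ring. The rest of the structure is the same in all three, so they also show nothing about how changes elsewhere on the shared core would move the number.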